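From Compound 2 to Compound 3 in a Whole-Animal Test

The source may report more compounds than this note shows. Statements on the series, on what has been measured and on what is new or still open speak of the compounds shown alone.

Compound 2 `CCC1(CCCCN2CCN(c3ccc(C)c(Cl)c3)CC2)C(=O)Nc2ccccc21` is examined in a functional assay on the whole organism (strain Wistar) with Rattus norvegicus as the target, with a stated time of 5 min; a higher number here means that more compound is needed for the effect, a lower number that less compound is needed. Compound 2 gives > 20 mg/kg, which is a limit of the assay rather than a number. Going by the values given here, its one neighbour differing in a single place is compound 1 `CCC1(CCCCN2CCN(c3cccc(OC)c3)CC2)C(=O)Nc2ccccc21`. In this assay compound 1 gives > 20 mg/kg, again a limit. The step that the two limits leave unreadable from compound 1 to compound 2 therefore cannot be read, and the limit of > 20 mg/kg in this assay, at which 2 of the 2 values shown sit, is all the evidence on it. Compound 3 `CCC1(CCCCN2CCN(c3ccc(F)cc3)CC2)C(=O)Nc2ccccc21` differs from compound 2 as follows: 4-fluorophenyl in place of 3-chloro-4-methylphenyl on an amine nitrogen in a ring. Among the compounds with values here, no readable measured step bears on this change; the only recorded step is unreadable, so no direction can be drawn from it. As both measured compounds sit at the limit, compound 3 is expected to sit near it too, and the step of a number no higher from compound 2 to compound 3 (the limit leaves the size open) is expected to be small. Compound 3 is estimated at 20 mg/kg, between 8 mg/kg and 50 mg/kg, with a fair chance that only a limit is reported.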

Compound 3, minimum effective dose: 10 mg/kg
For compound 3 the middle estimate is 2.0-fold (0.30 log units) above the measured one; the measured number falls inside the stated range.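

Going by these compounds alone, compound 3 gives the first real number in this assay, which shows that this place, on an amine nitrogen in a ring, can carry a group that brings a measurable effect, here 4-fluorophenyl. Only lower bounds can be read for the change: an at least 2.0-fold lower number from compound 2 to compound 3 (0.30 log units; that floor lies within the scatter), and an at least 2.0-fold lower number from compound 1 to compound 3 (0.30 log units; that floor lies within the scatter). Compound 1 and compound 2 remain limits of the assay, so the true size of either step stays unknown and neither floor goes beyond the scatter: the limit of > 20 mg/kg in this assay, at which 2 of the 3 values shown sit.

The compounds shown leave open whether the fluorine itself matters or only the absence of the chlorine, methyl or methoxy groups. Within the data shown here, a plain phenyl or a 4-chlorophenyl on the same nitrogen would separate these readings, and any number for such a compound would have to be read against the single value of compound 3.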